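The compounds below may be only part of what the source reports. "The series", "measured", "known", "first", "only" and "open" are said of these compounds alone.

The measured compounds:

Compound 1, `FC(F)(F)c1ccc(CSc2nc(N3CCCCC3)c3ccccc3n2)cc1` — in a functional assay on MGC-803 cells (Homo sapiens) for cytotoxicity, read by MTT assay, with a stated time of 72 h (a lower number here means a stronger inhibitor, a higher number a weaker inhibitor), compound 1 gives 18600 nM.
Compound 2, `COc1ccccc1Nc1nc(SCc2ccc(C(F)(F)F)cc2)nc2ccccc12` — in this assay compound 2 reaches only the limit of > 50000 nM.
Compound 3, `O=[N+]([O-])c1cccc(Nc2nc(SCc3ccc(C(F)(F)F)cc3)nc3ccccc23)c1` — in this assay compound 3 likewise reaches only the limit of > 50000 nM.

Among the measured compounds shown here, compound 1 thus holds the only numeric value of the three; the other two sit at the limit of > 50000 nM in this assay, at which 2 of the 3 values shown sit, so compound 1 is the reference point from which every comparison starts.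

Compound 4, `COc1ccc(Nc2nc(SCc3ccc(C(F)(F)F)cc3)nc3ccccc23)c(OC)c1`, differs from compound 1 by (2,4-dimethoxyphenyl)amino in place of piperidin-1-yl on an aromatic carbon. For the measured compounds named here, two measured steps bear directly on this change, because both an at least 2.6-fold higher number from compound 1 to compound 2 (0.42 log units; beyond the scatter) and an at least 2.6-fold higher number from compound 1 to compound 3 (0.42 log units; beyond the scatter) replace the same piperidin-1-yl with an arylamino group and both run to the limit. The pair of limits leaves a step that the two limits leave unreadable from compound 2 to compound 3, so nothing separates the two arylamino variants from each other. Going by the values given here, compound 2 already carries a (2-methoxyphenyl)amino group, and compound 4 adds a second methoxy to that pattern; the closest precedent therefore points to a weakening of at least the same size.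

Compound 4 is accordingly expected to give 60000 nM in this assay. The expected range for compound 4 runs from 20000 nM to 200000 nM. The estimated step is a 3.2-fold higher number from compound 1 to compound 4 (0.51 log units; beyond the scatter), and the outcome most probably appears again only as a limit.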

Compound 4, half-maximal inhibitory concentration: > 50000 nM
Compound 4 ended at the assay's limit; the forecaster's own chance of this, stated with the estimate: 75%; the middle value is on the limit's open side.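

In this assay, a third arylamino group on this aromatic carbon, next to the ring nitrogen, gives the same picture as the first two: the change to (2,4-dimethoxyphenyl)amino produces an at least 2.6-fold higher number from compound 1 to compound 4 (0.42 log units; beyond the scatter). Adding a methoxy to the (2-methoxyphenyl)amino group of compound 2 does not bring back a numeric value, and the steps among compound 2, compound 3 and compound 4 cannot be read, as all three values are limits. Among the compounds shown, piperidin-1-yl is the only group at this position that gives a number, and no compound goes against this, while the arylamino compounds all end at the same limit: the limit of > 50000 nM in this assay, at which 3 of the 4 values shown sit.

On these data alone, how far past that limit compound 2, compound 3 and compound 4 lie remains unknown, and the substituents on their aromatic rings cannot be ranked against one another. As far as these compounds go, it also remains open whether the numeric value belongs to piperidin-1-yl alone or extends to other amines at this position, such as morpholin-4-yl, pyrrolidin-1-yl or an open-chain amine like diethylamino.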